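Adding methoxy to the phenyl of compound 3

A few compounds are considered here, and "the series" means these few. Any claim that something is new, unique, unknown or untested is made for them only; others in the source may bear on it.

In a physicochemical assay for solubility, in phosphate buffer, at pH 7.4 (a higher number here means a more soluble compound, a lower number a less soluble compound), compound 1 `CCOC(=O)c1c(-c2ccc(C(F)(F)F)cc2)[nH]c2cccc(OC)c2c1=O` gives 22000 nM and compound 2 `CCOC(=O)c1c(-c2ccc(C(C)(C)C)cc2)[nH]c2cccc(OC)c2c1=O` gives 1000 nM. Compound 3 `CCOC(=O)c1c(-c2ccccc2)[nH]c2cccc(OC)c2c1=O` gives > 100000 nM, which is a limit of the assay and not a number. It therefore stands at the limit of > 100000 nM in this assay, at which 1 of the 3 values shown sits. Compound 4 `CCOC(=O)c1c(-c2cccc(OC)c2)[nH]c2cccc(OC)c2c1=O` has methoxy in place of hydrogen on an aromatic carbon, meta to a large group (methoxy in place of hydrogen on an aromatic carbon). For the measured compounds named here, two measured steps bear on this change. Hydrogen in place of trifluoromethyl gave an at least 4.5-fold higher number from compound 1 to compound 3 (0.65 log units; beyond the scatter), and hydrogen in place of tert-butyl gave an at least 100-fold higher number from compound 2 to compound 3 (2.00 log units; beyond the scatter). Both end at compound 3, so a modest drop is expected when methoxy enters. The expected size is an at least 2.2-fold lower number from compound 3 to compound 4 (0.34 log units; beyond the scatter). For compound 4 the estimate is 45000 nM, with an expected range of 10000 nM to 100000 nM.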

Compound 4, solubility: > 100000 nM
Compound 4: only a limit was reported; the forecaster's own chance of this, stated with the estimate: 30%; at least 2.2-fold (0.34 log units) between middle value and limit.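

In this assay compound 4 gives > 100000 nM, a limit of the assay, as compound 3 does, so no step can be read between the two: the limit of > 100000 nM in this assay, at which 2 of the 4 values shown sit. The compounds shown leave open whether methoxy in place of hydrogen changes the number in this assay at all.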